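Pyrrolidin-1-yl in place of piperidin-1-yl in compound 2

The compounds below may be only part of what the source reports. "The series", "measured", "known", "first", "only" and "open" are said of these compounds alone.

Compound 1 (`CCCCCCC[C@H](O)C/C=C/CCC(=O)NCC(C)C`) and compound 2 (`CCCCCCC[C@H](O)C/C=C/CCC(=O)N1CCCCC1`) share one core and differ only in the group on a carbonyl carbon. In a functional assay on HeLa cells (Homo sapiens) for inhibition, read by trypan blue exclusion, with a stated time of 48 h (on this read-out higher numbers stand for weaker inhibition and lower numbers for stronger inhibition), compound 1 gives > 100000 nM, which is a limit of the assay and not a number. In this assay compound 2 gives > 100000 nM, which is also a limit. Among the compounds with values here, the one measured exchange at this place, a step that the two limits leave unreadable from compound 1 to compound 2, therefore has no size that can be read. All the evidence is the limit of > 100000 nM in this assay, at which 2 of the 2 values shown sit.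

Compound 3 (`CCCCCCC[C@H](O)C/C=C/CCC(=O)N1CCCC1`) changes compound 2 in one place: pyrrolidin-1-yl in place of piperidin-1-yl on a carbonyl carbon. Pyrrolidin-1-yl stands in place of piperidin-1-yl on a carbonyl carbon. With no readable step to go on, no shift beyond the scatter and no direction is expected in this assay. The estimated step is a step that the limit leaves unreadable from compound 2 to compound 3. For compound 3 the expected value is 120000 nM, within an estimated range of 50000 nM to 300000 nM.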

Compound 3, half-maximal inhibitory concentration: > 100000 nM
Compound 3 ended at the assay's limit (the forecaster's own chance of this, stated with the estimate: 80%); the middle value is on the limit's open side.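

In this assay compound 3 gives > 100000 nM, which is a limit and not a number. No step among compound 1, compound 2 and compound 3 can be read, and all the evidence is this: the limit of > 100000 nM in this assay, at which 3 of the 3 values shown sit.

The compounds shown leave open whether any group on the carbonyl carbon would give a readable value.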